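Methyl for chloro on the benzylsulfonyl arm

The source may report more compounds than this note shows. Statements on the series, on what has been measured and on what is new or still open speak of the compounds shown alone.

Compound 1 `N#Cc1cc2c(nc1N1CCC(F)(C(=O)NS(=O)(=O)Cc3ccc(Cl)cc3)CC1)COC2=O` gives 37200 nM in a functional assay (Platelet, plasma) for inhibition, with Homo sapiens as the target; on this read-out lower numbers stand for stronger inhibition and higher numbers for weaker inhibition. Going by the values given here, the only other number belongs to compound 2 `N#Cc1cc2c(nc1N1CCC(C(=O)NS(=O)(=O)Cc3cc(Cl)cc(Cl)c3)CC1)COC2=O`, which in this assay gives 30500 nM; compound 1 thus holds the higher of the two numbers, yet its gap to compound 2 lies within the scatter. Compound 3 `Cc1ccc(CS(=O)(=O)NC(=O)C2(F)CCN(c3nc4c(cc3C#N)C(=O)OC4)CC2)cc1` is not yet measured. It differs from compound 1 by methyl in place of chloro on an aromatic carbon. Among the compounds with values here, no step between measured compounds is available to size such a swap; a change not beyond the scatter is expected, in no preferred direction. Compound 3 is therefore estimated at 35000 nM in this assay, with a range from 12000 nM to 100000 nM, a step of a 1.1-fold lower number from compound 1 to compound 3 (0.03 log units; within the scatter).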

Compound 3, half-maximal inhibitory concentration: 32800 nM
Compound 3: the middle estimate sits 1.1-fold (0.03 log units) above what was measured, within the range that was stated.
By their numbers in this assay, from the lowest: compounds 2, 3 and 1 (each within the scatter of the next).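

In this assay, going by these compounds alone, the change from 4-chlorobenzyl to 4-methylbenzyl gives a 1.1-fold lower number from compound 1 to compound 3 (0.05 log units; within the scatter) and so provides the first sized step at this para position. Methyl in place of chloro leaves the number within the scatter, at least on the fluorinated compound 1. No supporting measurement bears on this result.

Going by these compounds, whether an amine, a carboxylic acid or a longer chain at this position would move the number beyond the scatter stays open. Also open, on these data alone, is whether the same swap behaves alike without the fluorine on the shared core.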